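The source may hold more compounds than are shown below. What is called first, only, known or untested is meant among the compounds shown, and "the series" means these compounds.

Measured compounds in a functional assay on HeLa cells (Homo sapiens) for inhibition, read by sulforhodamine B assay, with a stated time of 48 h; on this read-out higher numbers stand for weaker inhibition of growth and lower numbers for stronger inhibition of growth:
compound 1 `COC(=O)[C@@]1(C)CCC=C2[C@@H]1CC[C@@H](C)[C@]2(C)Cc1c[nH]c2ccccc12` gives 3600 nM
compound 2 `COC(=O)[C@@]1(C)CCC=C2[C@@H]1CC[C@@H](C)[C@]2(C)Cc1c[nH]c2ccc(Cl)cc12` gives 11000 nM
compound 3 `COC(=O)[C@@]1(C)CCC=C2[C@@H]1CC[C@@H](C)[C@]2(C)Cc1c[nH]c2c(Br)cccc12` gives 13000 nM

Compound 1 holds the lowest of the three numbers in this assay. Its two neighbours both carry a halogen on an aromatic carbon of the shared core: the step of a 3.1-fold higher number from compound 1 to compound 2 (0.49 log units; beyond the scatter) and the step of a 3.6-fold higher number from compound 1 to compound 3 (0.56 log units; beyond the scatter) are each modest, in the same direction, and beyond the scatter.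

Compound 4 `COC(=O)[C@@]1(C)CCC=C2[C@@H]1CC[C@@H](C)[C@]2(C)Cc1c(C)[nH]c2ccccc12` is the next case. It differs from compound 1 by methyl in place of hydrogen on an aromatic carbon, that is, on an aromatic carbon of the five-membered aromatic ring with one nitrogen, next to the ring nitrogen and next to the ring atom that bears the large group. Going by the values given here, no measured step touches that place or that group. Among the compounds with values here, the only steps on hand are the two halogen substitutions on compound 1, both of which raised the number modestly, so a small move upward is the more likely outcome, though a result within the scatter of compound 1 cannot be ruled out. The step expected is a 1.5-fold higher number from compound 1 to compound 4 (0.18 log units; within the scatter). Compound 4 is therefore estimated at 5500 nM in this assay, with a range from 2000 nM to 15000 nM.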

Compound 4, concentration for 50% growth inhibition: 11000 nM
The estimate for compound 4 lay 2.0-fold (0.30 log units) below the measured number; measured number inside the range.
By their numbers in this assay, from the lowest: compound 1; then compounds 2, 4 and 3 (each within the scatter of the next).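

In this assay, methyl on this aromatic carbon, next to the ring nitrogen and next to the ring atom that bears a large group, gives a 3.1-fold higher number from compound 1 to compound 4 (0.49 log units; beyond the scatter), so even a single added carbon at this place moves the number towards weaker inhibition of growth. The upward move on compound 1 is therefore not limited to halogens or to the places they occupy: all three substitutions shown on compound 1 raise the number, by steps that are modest and beyond the scatter, and no compound shown goes against this. Nothing on hand bears on why methyl at this place has this effect.

The compounds shown leave open whether the rise at this place is particular to methyl or also holds for a longer chain such as ethyl, for a halogen such as chloro, or for a group such as an amine or a carboxylic acid. They also leave open whether methyl at this place and a halogen elsewhere on the shared core would add up when carried together, or whether the methyl ester of the shared core has any bearing on these steps.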